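A few compounds are considered here, and "the series" means these few. Any claim that something is new, unique, unknown or untested is made for them only; others in the source may bear on it.

In an ADME assay on HepG2 cells (Homo sapiens) for cytotoxicity, with a stated time of 72 h (a higher number here means that more compound is needed for the effect, a lower number that less compound is needed), compound 1 `Cc1cc(NC(=O)Nc2ccc(Cl)c(Cl)c2)c2ccccc2n1` gives 17000 nM. Compound 2 `COc1ccc(NC(=O)Nc2cc(C)nc3ccccc23)cc1Cl` is the same molecule with methoxy in place of chloro on an aromatic carbon. Compound 2 reaches only a limit of the assay in this assay, > 25000 nM. That change therefore gives an at least 1.4-fold higher number from compound 1 to compound 2 (0.16 log units; that floor lies within the scatter), and how much farther it may go is hidden by the limit of > 25000 nM in this assay, at which 2 of the 3 values shown sit. Compound 3 `Cc1cc(NC(=O)Nc2ccc(Cl)cc2)c2ccccc2n1` differs from compound 1 by hydrogen in place of chloro on an aromatic carbon. Compound 3 also stops at a limit in this assay, > 25000 nM. The step is accordingly an at least 1.4-fold higher number from compound 1 to compound 3 (0.16 log units; that floor lies within the scatter).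

Compound 4 `COc1ccc(NC(=O)Nc2cc(C)nc3ccccc23)cc1` has not yet been measured in this assay. It relates to compound 3 as compound 2 relates to compound 1, by methoxy in place of chloro on an aromatic carbon. This is the same kind of change, not the same one: in compound 1 the place is also ortho to a chloro group (1 heavy atom), whereas in compound 3 the place carries no such chloro group. For the measured compounds named here, the earlier occurrence of the change is the only guide available, and it reads as a floor only.

For compound 4 the expected step is a step that the limit leaves unreadable from compound 3 to compound 4, resting on the earlier step of an at least 1.4-fold higher number from compound 1 to compound 2 (0.16 log units; that floor lies within the scatter), which carried compound 2 to the limit. The estimate for compound 4 is 35000 nM, with an expected range from 15000 nM to 90000 nM, and it is expected that this assay will most likely report only a limit again.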

Compound 4, half-maximal effective concentration: > 25000 nM
Compound 4: a limit, no number; the forecaster's own chance of this, stated with the estimate: 80%; the middle value lies beyond the limit too.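

In this assay compound 4 gives > 25000 nM as a limit of the assay, so its steps from compound 3 and from compound 2 cannot be read: the limit of > 25000 nM in this assay, at which 3 of the 4 values shown sit.

Compound 2, compound 3 and compound 4 therefore leave open whether these three differ from one another at all, and how large either change would be if the values could be read as numbers.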